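Replacing carboxy with (4-chlorophenyl)carbamoyl in compound 1

A few compounds are considered here, and "the series" means these few. Any claim that something is new, unique, unknown or untested is made for them only; others in the source may bear on it.

In a functional assay on NCI-H460 cells (Homo sapiens) for inhibition, read by MTT assay, with a stated time of 24 h, tested at 0.1 ug/mL (on this read-out lower numbers stand for less inhibition of growth and higher numbers for more inhibition of growth at the one concentration tested), compound 1 (`O=C(O)CCCCC(CCSC(=O)c1ccccc1)SC(=O)c1ccccc1`) is recorded as "not active" (no number reported) and carries no number, so it gives no numeric starting point for the series. Going by the values given here, the only number so far belongs to compound 2 (`O=C(CCCCC(S)CCS)Nc1ccc([N+](=O)[O-])cc1`), which reads 5.69% in this assay at the single concentration tested. The next compound to be read is compound 3 (`O=C(CCCCC(CCSC(=O)c1ccccc1)SC(=O)c1ccccc1)Nc1ccc(Cl)cc1`). Its change from compound 1 is (4-chlorophenyl)amino in place of hydroxy on a carbonyl carbon and puts (4-chlorophenyl)amino in place of hydroxy on a carbonyl carbon. Among the compounds with values here, no measured step covers this change. Within the data shown here, only a small upward move in this assay is expected, probably not beyond the usual scatter, and the sole reading of compound 2 at 5.69% offers no support for a larger one. For compound 3 the estimated inhibition is 10% (expected range 0% to 30%).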

Compound 3, percent growth inhibition at one concentration: 9.36%
For compound 3 the middle estimate is 0.6 percentage points above the measured one, and the stated range covers the measured number.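

In this assay compound 1 stands at "not active" (no number reported) and compound 3 at 9.36% and so no step can be read between compound 1 and compound 3. From the compounds shown here alone, what (4-chlorophenyl)carbamoyl in place of carboxy does to growth inhibition stays open. No measurement at hand explains the reading of compound 3.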